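Replacing the Aryl Group on a Piperazine Thiosemicarbazide

The compounds below may be only part of what the source reports. "The series", "measured", "known", "first", "only" and "open" are said of these compounds alone.

Three compounds share a core in which an oxindole is joined through a thiosemicarbazide to a piperazine that carries an aromatic ring. Compound 1, `O=C1Nc2ccccc2/C1=N/NC(=S)N1CCN(c2ccccc2)CC1`, gives 18600 nM in a functional assay on A549 cells (Homo sapiens) for inhibition, read by MTT assay, with a stated time of 72 h; a higher number here means a weaker inhibitor, a lower number a stronger inhibitor. Compound 2, `O=C1Nc2cc(Cl)ccc2/C1=N/NC(=S)N1CCN(c2ccccc2)CC1`, gives 27700 nM, and the step of a 1.5-fold higher number from compound 1 to compound 2 (0.17 log units; within the scatter). Compound 3, `Cc1ccccc1N1CCN(C(=S)N/N=C2\C(=O)Nc3ccc(Cl)cc32)CC1`, gives 6520 nM, the lowest of the three numbers and therefore the strongest inhibitor here, since its gaps to compound 1 and compound 2 both lie beyond the scatter.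

Compound 4, `O=C1Nc2ccc(Cl)cc2/C1=N/NC(=S)N1CCN(c2ccc([N+](=O)[O-])cc2)CC1`, has not yet been measured. It differs from compound 3 in one place: 4-nitrophenyl in place of 2-methylphenyl on an amine nitrogen in a ring. Going by the values given here, no measured step concerns this position. Among the compounds with values here, the only step available, from compound 1 to compound 2, concerns a chloro on the aromatic core and was within the scatter, so it says nothing about exchanging the aryl group on the piperazine. Compound 1 and compound 3 differ in two places at once, so their values cannot be split into single changes. Within the data shown here, with no direct precedent, compound 4 is expected to stay near compound 3, with a step of a 1.4-fold higher number from compound 3 to compound 4 (0.14 log units; within the scatter) and wide uncertainty. The estimate for compound 4 is 9000 nM, within a range from 3000 nM to 30000 nM.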

Compound 4, half-maximal inhibitory concentration: 11800 nM
For compound 4 the middle estimate is 1.3-fold (0.12 log units) below the measured one, and the stated range covers the measured number.
By their numbers in this assay, from the lowest: compounds 3, 4, 1 and 2 (each within the scatter of the next, the first and the last beyond it).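

Going by these compounds alone, this is the only step that changes the aromatic group alone: in this assay, 4-nitrophenyl in place of 2-methylphenyl on an amine nitrogen in a ring gives a 1.8-fold higher number from compound 3 to compound 4 (0.26 log units; within the scatter) and so cannot be told apart from repeat measurements. Within the data shown here, this position therefore tolerates an exchange in which the entering group has 2 hydrogen-bond acceptors and the leaving group has 0, with no step that rises above the scatter, and compound 3 no longer stands apart as the single best compound. Nothing available bears on what lies behind this result.

The two groups differ both in their substituent and in where it sits on the aromatic ring, so the compounds shown cannot separate those two changes; 4-methylphenyl or 2-nitrophenyl on the same nitrogen would pull them apart. Also open, from the compounds shown here alone, is how the number would respond to a larger departure at this position, such as a benzyl group, an aromatic ring carrying an amine or a carboxylic acid, or a simple alkyl chain in place of the aromatic ring.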